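This account rests on a few compounds, and the source may have more. Where it says the series, first, only, none or still open, it means among the compounds named here.

Compound 1 `COc1cc(/C(=C\c2cn(C(C)=O)c3ccc(OCc4ccccc4)cc23)C(=O)O)cc(OC)c1OC`: 57100 nM
Compound 2 `COc1ccc(/C(=C\c2cn(C(C)=O)c3ccc(OCc4ccccc4)cc23)C(=O)O)cc1OC`: 65500 nM

Both compounds were tested in a functional assay on M14 cells (Homo sapiens) for cytotoxicity, read by MTT assay, with a stated time of 72 h; a lower number here means a stronger inhibitor, a higher number a weaker inhibitor. Compound 2 gives 65500 nM, the highest of the two numbers shown; its nearest neighbour is compound 1, and the step from compound 1 to compound 2 is a 1.1-fold higher number from compound 1 to compound 2 (0.06 log units; within the scatter), so the two cannot be told apart on these numbers. Compound 3 `COc1cc(OC)cc(/C(=C\c2cn(C(C)=O)c3ccc(OCc4ccccc4)cc23)C(=O)O)c1` has not yet been measured in this assay. It differs from compound 2 in one place: 3,5-dimethoxyphenyl in place of 3,4-dimethoxyphenyl on a double-bonded chain carbon bound to a carbonyl carbon and a double-bonded chain carbon. Among the measured compounds shown here, only one measured step bears on this, the removal of a methoxy from the same ring, and it was a 1.1-fold higher number from compound 1 to compound 2 (0.06 log units; within the scatter). Since even taking a methoxy group away left the number within the scatter, moving one is expected to change little, and the step from compound 2 to compound 3 is estimated as a 1.0-fold lower number from compound 2 to compound 3 (0.00 log units; within the scatter). Compound 3 is therefore expected to give about 65000 nM in this assay, with a range from 30000 nM to 140000 nM.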

Compound 3, half-maximal inhibitory concentration: 94000 nM
For compound 3 the middle estimate is 1.4-fold (0.16 log units) below the measured one; the measured number falls inside the stated range.
By their numbers in this assay, from the lowest: compounds 1, 2 and 3 (each within the scatter of the next).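

In this assay the change to 3,5-dimethoxyphenyl in place of 3,4-dimethoxyphenyl on the double-bonded chain carbon gives a 1.4-fold higher number from compound 2 to compound 3 (0.16 log units; within the scatter) and so does not separate these two arrangements of the methoxy groups. Among the compounds shown here, compound 3 also lacks a different methoxy from the one missing in compound 2, and that removal gives a 1.6-fold higher number from compound 1 to compound 3 (0.22 log units; within the scatter) so on these numbers neither removal can be told apart from compound 1, and all three compounds stay within the scatter of one another. Nothing available here offers a reason for these numbers.

Still open, on these data alone, is whether any other group on this ring, such as a hydroxyl or an amine in place of a methoxy, would move the number beyond the scatter. Equally open, as far as these compounds go, is what a methyl ester or an amide would do in place of the carboxylic acid that all three compounds share.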